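A few compounds are considered here, and "the series" means these few. Any claim that something is new, unique, unknown or untested is made for them only; others in the source may bear on it.

Among the three compounds measured so far, compound 3 `CN1CCN(c2ccc(Nc3ncc4nc(Nc5ccc(F)cc5)n([C@H]5CCCN(S(=O)(=O)C6CC6)C5)c4n3)cc2)CC1` holds the lowest number in a functional assay on HCC827 cells (Homo sapiens) for antiproliferative activity, read by MTT assay, with a stated time of 72 h (a higher number here means a weaker inhibitor, a lower number a stronger inhibitor), giving 8.6 nM. Its nearest neighbour is compound 1 `CN1CCN(c2ccc(Nc3ncc4nc(Nc5ccccc5)n([C@H]5CCN(S(C)(=O)=O)C5)c4n3)cc2)CC1`, which in this assay gives 17 nM, a gap that lies within the usual scatter. Furthest away is compound 2 `CN1CCN(c2ccc(Nc3ncc4nc(Nc5ccc(F)cc5)n([C@H]5CCNC5)c4n3)cc2)CC1`, which in this assay gives 1220 nM; the step of a 140-fold lower number from compound 2 to compound 3 (2.15 log units; beyond the scatter) is large and well beyond the scatter.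

Compound 4 `CN1CCN(c2ccc(Nc3ncc4nc(Nc5ccc(F)cc5)n([C@@H]5CCN(C(=O)OC(C)(C)C)C5)c4n3)cc2)CC1` is the next structure, differing from compound 3 in one place: 1-(tert-butoxycarbonyl)pyrrolidin-3-yl in place of 1-(cyclopropylsulfonyl)piperidin-3-yl on an aromatic nitrogen. Going by the values given here, the single step that bears on this change is the one from compound 2 to compound 3, where capping the ring nitrogen brought a large drop. Compound 4 keeps a capped ring nitrogen, so the large loss seen for compound 2 is not expected to recur, but the two numbers shown for compound 1 and compound 3 give no direct guide to the tert-butoxycarbonyl group. A moderate rise, a 4.7-fold higher number from compound 3 to compound 4 (0.67 log units; beyond the scatter), is therefore expected. Compound 4 is estimated at 40 nM in this assay, with a range from 10 nM to 200 nM.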

Compound 4, half-maximal inhibitory concentration: 27 nM
For compound 4 the middle estimate is 1.5-fold (0.17 log units) above the measured one; low and high end bracket the measured number.
By their numbers in this assay, from the lowest: compounds 3, 1 and 4 (each within the scatter of the next, the first and the last beyond it); then compound 2.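

In this assay, 1-(tert-butoxycarbonyl)pyrrolidin-3-yl in place of pyrrolidin-3-yl gives a 45-fold lower number from compound 2 to compound 4 (1.65 log units; beyond the scatter) on the same five-membered ring, so a large step on capping the ring nitrogen does not need a sulfonyl group or a six-membered ring. Between the two capped compounds the exchange gives only a 3.1-fold higher number from compound 3 to compound 4 (0.50 log units; beyond the scatter) and it changes the ring and the cap together, so the step cannot be assigned to either one. Nothing at hand accounts for either step.

The compounds shown leave open how 1-(cyclopropylsulfonyl)pyrrolidin-3-yl would compare, which would separate ring size from the cap. They also leave open whether a cap as small as a methyl or an acetyl on the ring nitrogen would bring a step of similar size from compound 2.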